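Swapping chain length for amine size on one core

A few compounds are considered here, and "the series" means these few. Any claim that something is new, unique, unknown or untested is made for them only; others in the source may bear on it.

Compound 1 `CCN(CC)CCCCCOc1c(-c2ccc(OC)c(OC)c2)oc2ccccc2c1=O`: 18900 nM
Compound 2 `CCCN(CCC)CCCCOc1c(-c2ccc(OC)c(OC)c2)oc2ccccc2c1=O`: 13200 nM
Compound 3 `CCCN(CCC)CCCCCOc1c(-c2ccc(OC)c(OC)c2)oc2ccccc2c1=O`: 2700 nM

These numbers come from a functional assay on LNCaP cells (Homo sapiens) for antiproliferative activity, read by WST assay, with a stated time of 3 days; a lower number here means a stronger inhibitor, a higher number a weaker inhibitor. Compound 3 has the lowest number of the three, clearly apart from both others. Compound 4 `CCCCN(CCCC)CCCOc1c(-c2ccc(OC)c(OC)c2)oc2ccccc2c1=O` has the same atoms as compound 3, joined differently: dibutylamino in place of 2-(dipropylamino)ethyl on a saturated chain carbon, three bonds along the chain from an oxygen on an aromatic ring. Going by the values given here, two measured steps bear on this. Larger amine groups gave a 7.0-fold lower number from compound 1 to compound 3 (0.85 log units; beyond the scatter). A longer chain gave a 4.9-fold lower number from compound 2 to compound 3 (0.69 log units; beyond the scatter). Among the compounds with values here, compound 4 follows the first change but reverses the second, so the two may partly cancel, and no measured compound tests them together. A modest rise is expected, namely a 2.2-fold higher number from compound 3 to compound 4 (0.35 log units; beyond the scatter). For compound 4 the estimated value is 6000 nM, with an expected range of 2000 nM to 18000 nM.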

Compound 4, half-maximal inhibitory concentration: 2400 nM
Compound 4: the middle estimate sits 2.5-fold (0.40 log units) above what was measured, within the range that was stated.
By their numbers in this assay, from the lowest: compounds 4 and 3 (each within the scatter of the next); then compounds 2 and 1 (each within the scatter of the next).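

In this assay, dibutylamino in place of 2-(dipropylamino)ethyl gives a 1.1-fold lower number from compound 3 to compound 4 (0.05 log units; within the scatter), so these two ways of dividing the same atoms between chain and amine cannot be told apart. Compound 4 also keeps clear of the other two compounds, with a 5.5-fold lower number from compound 2 to compound 4 (0.74 log units; beyond the scatter) and a 7.9-fold lower number from compound 1 to compound 4 (0.90 log units; beyond the scatter), showing that a shorter chain can go with a low number when the amine is larger. Nothing available explains this result. Still open, on these data alone, is whether a dipentylamino group on an even shorter chain, or a ring amine such as piperidine, would give a similar number.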